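The source may report more compounds than this note shows. Statements on the series, on what has been measured and on what is new or still open speak of the compounds shown alone.

Measured compounds:
compound 1 `CCCSc1nc(N/N=C/c2ccccc2Cl)c2nnn(Cc3ccccc3)c2n1`: 6180 nM
compound 2 `CCCSc1nc(N/N=C(\C)c2ccccc2O)c2nnn(Cc3ccccc3Cl)c2n1`: > 64000 nM
compound 3 `CCCSc1nc(N/N=C/c2cccc(Cl)c2)c2nnn(Cc3ccccc3)c2n1`: > 64000 nM

In a functional assay on ECa-109 cells (Homo sapiens) for antiproliferative activity, read by MTT assay, with a stated time of 72 h (a lower number here means a stronger inhibitor, a higher number a weaker inhibitor), compound 1 gives 6180 nM. Among the measured compounds shown here, that is the only plain number among the three compounds. For compound 2 the result is a limit of the assay, > 64000 nM. For compound 3 the result is likewise a limit, > 64000 nM. So compound 1 stands as the one compound with a measurable value, and the other two sit at the limit of > 64000 nM in this assay, at which 2 of the 3 values shown sit.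

The unmeasured compound 4 `CCCSc1nc(N/N=C(\C)c2ccccc2O)c2nnn(Cc3ccccc3)c2n1` is reached from compound 1 by a group of 10 heavy atoms (8 carbon, 1 nitrogen, 1 oxygen; one six-membered aromatic ring of carbon only) in place of a group of 9 heavy atoms (7 carbon, 1 nitrogen, 1 chlorine; one six-membered aromatic ring of carbon only), on a nitrogen on an aromatic ring.

For the measured compounds named here, only one measured step touches the same region of the shared core: an at least 10-fold higher number from compound 1 to compound 3 (1.01 log units; beyond the scatter), a large weakening. It shows that even a small rearrangement of this group can push a compound from a number to a limit. Going by the values given here, the entering group of compound 4 is also present in compound 2, which sits at a limit, although compound 2 differs from compound 4 elsewhere, so no direct step can be drawn between them.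

On that basis a weakening is expected from compound 1 to compound 4, of roughly a 6.5-fold higher number from compound 1 to compound 4 (0.81 log units; beyond the scatter) in this assay, with a real chance that only a limit is reported. Compound 4 is therefore estimated at 40000 nM, within a range from 6000 nM to 200000 nM.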

Compound 4, half-maximal inhibitory concentration: 11100 nM
Compound 4: the middle estimate sits 3.6-fold (0.56 log units) above what was measured; the measured number falls inside the stated range.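

In this assay, a 1.8-fold higher number from compound 1 to compound 4 (0.25 log units; within the scatter), so the group of 10 heavy atoms, with its oxygen and a hydrogen-bond donor, can stand on this nitrogen on an aromatic ring in place of the chlorine-bearing group of 9 heavy atoms without a change that can be told from the scatter. The same exchange gives an at least 5.7-fold lower number from compound 3 to compound 4 (0.76 log units; beyond the scatter), which shows that the loss of activity seen in compound 3 is not shared by every replacement of the group of compound 1 at this place. The third comparison, an at least 5.7-fold lower number from compound 2 to compound 4 (0.76 log units; beyond the scatter), adds something new: compound 2 carries the same entering group as compound 4, so that group alone does not bring a compound to the limit, and hydrogen in place of chloro on an aromatic carbon elsewhere in the molecule matters as well.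

Compound 2 and compound 3 remain limits rather than numbers, so the true size of these two steps is unknown: the limit of > 64000 nM in this assay, at which 2 of the 4 values shown sit. The exchange also alters several features at once, and the compounds shown neither separate them nor tell what an amine or a carboxylic acid on the same aromatic ring would do.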